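Shortening the Link to the Imide Ring in an Aryl-Pyridone Series

The source may hold more compounds than are shown below. What is called first, only, known or untested is meant among the compounds shown, and "the series" means these compounds.

Measured compounds:
compound 1, `CC(C)C(CC1C(=O)NC(=O)N1C)c1ccc(-c2ccc3cccc(F)c3c2)[nH]c1=O`, 17 nM
compound 2, `CC(C)[C@@H](c1ccc(-c2ccc3cccc(F)c3c2)[nH]c1=O)[C@@H]1OC(=O)NC1=O`, 85 nM
compound 3, `CCC(/C=C1\OC(=O)NC1=O)(CC)c1ccc(-c2ccc3cccc(F)c3c2)[nH]c1=O`, 13 nM

The three measured compounds share a common core and differ in the cyclic imide group and in how it is attached to the chain. In an assay on membranes from Chem-1 cells for displacement of a labelled ligand from prostaglandin E2 receptor EP3 subtype (Homo sapiens), read by scintillation counting, with a stated time of 2 h (a lower number here means a stronger inhibitor, a higher number a weaker inhibitor), compound 1 gives 17 nM, the second highest number of the three. Its nearest neighbour is compound 3, which gives 13 nM, a difference that lies within the scatter, so the two cannot be ordered. Compound 2 gives 85 nM, a number beyond the scatter higher than that of compound 1.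

The new compound 4, `CC(C)C(c1ccc(-c2ccc3cccc(F)c3c2)[nH]c1=O)C1SC(=O)NC1=O`, comes from compound 1 by the change (2,4-dioxo-1,3-thiazolidin-5-yl in place of (3-methyl-2,5-dioxoimidazolidin-4-yl)methyl on a saturated chain carbon bound to an aromatic carbon and a saturated chain carbon). Among the compounds with values here, no measured pair shows this exact step, so its size is not known from the data. Compound 2 is the closest measured analogue in build to compound 4, and in this assay compound 2 gives 85 nM. On that basis the step is expected to move toward a higher number, beyond the scatter, and compound 4 is estimated at 50 nM, with a range from 15 nM to 160 nM, which corresponds to an expected step of a 2.9-fold higher number from compound 1 to compound 4 (0.47 log units; beyond the scatter).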

Compound 4, inhibition constant: 25 nM
The estimate for compound 4 lay 2.0-fold (0.30 log units) above the measured number; low and high end bracket the measured number.
By their numbers in this assay, from the lowest: compounds 3, 1 and 4 (each within the scatter of the next); then compound 2.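

In this assay, putting 2,4-dioxo-1,3-thiazolidin-5-yl in place of (3-methyl-2,5-dioxoimidazolidin-4-yl)methyl on this saturated chain carbon gives a 1.5-fold higher number from compound 1 to compound 4 (0.17 log units; within the scatter), so this exchange, which also brings the ring closer to the chain, leaves the number within the scatter of the parent. Among the earlier compounds, compound 2 alone carried its ring directly on this carbon and gave 85 nM, whereas compound 4, also directly attached, gives 25 nM, which shows that direct attachment does not by itself tie a compound to the number of compound 2. The data shown offer no measurement that explains this result.

From the compounds shown here alone, the step from compound 1 changes the ring and its link together, so it remains open what each contributes, and a 2,4-dioxo-1,3-thiazolidin-5-ylmethyl group or a directly attached 3-methyl-2,5-dioxoimidazolidin-4-yl group would be needed to separate them. Going by these compounds, it also remains open how a carboxylic acid or a primary amine would fare on this carbon, and whether the two separate stereoisomers of compound 4 would give the same number.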